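The compounds below may be only part of what the source reports. "The series", "measured", "known", "first", "only" and "open" are said of these compounds alone.

Three compounds share the same sulfonamide-linked core and differ only in where a fluorine sits on a phenyl ring or in how the two aromatic rings are joined. Compound 1 is `O=c1[nH]cc(S(=O)(=O)Nc2cccc(-c3cn(-c4cccc(F)c4)nn3)c2)c(=O)[nH]1`. Compound 2 is `O=c1[nH]cc(S(=O)(=O)Nc2cccc(-c3cn(-c4ccc(F)cc4)nn3)c2)c(=O)[nH]1`, and the change from compound 1 to compound 2 is 4-fluorophenyl in place of 3-fluorophenyl on an aromatic nitrogen. Compound 3 is `O=c1[nH]cc(S(=O)(=O)Nc2ccc(-c3cn(-c4cccc(F)c4)nn3)cc2)c(=O)[nH]1`; the difference between the core of compound 1 and the core of compound 3 is not broken down here.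

All three were tested in a functional assay on HepG2 cells (Homo sapiens) for antiproliferative activity, read by MTT assay, with a stated time of 24 h; on this read-out higher numbers stand for weaker inhibition and lower numbers for stronger inhibition. In this assay compound 1 gives only a limit, > 20000 nM. Compound 2 likewise gives only a limit, > 20000 nM. Compound 3 also gives only a limit, > 20000 nM. Because every value sits at the limit of > 20000 nM in this assay, at which 3 of the 3 values shown sit, the step that the two limits leave unreadable from compound 1 to compound 2 cannot be read, and no ordering among compound 1, compound 2 and compound 3 can be drawn from these results.

Compound 4 is `O=c1[nH]cc(S(=O)(=O)Nc2ccc(-c3cn(-c4ccc(F)cc4)nn3)cc2)c(=O)[nH]1` and has not yet been measured in this assay. The change from compound 3 to compound 4 is 4-fluorophenyl in place of 3-fluorophenyl on an aromatic nitrogen, the same change, at the same place, as that from compound 1 to compound 2. That earlier change led from one limit to another, so the same outcome is expected here. Compound 4 is expected to give about 30000 nM, somewhere from 15000 nM to 100000 nM, most probably reported again only as a limit. The step this expectation implies is a step that the limit leaves unreadable from compound 3 to compound 4, an estimate rather than a result.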

Compound 4, half-maximal inhibitory concentration: > 20000 nM
Compound 4: a limit, no number; the forecaster's own chance of this, stated with the estimate: 90%; the middle value does not contradict the limit.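

In this assay compound 4 gives > 20000 nM, which is a limit and not a number. The step from compound 3 to compound 4 therefore cannot be read, because both compounds stand at the same limit: the limit of > 20000 nM in this assay, at which 4 of the 4 values shown sit.

The compounds shown leave open how strongly any of the four inhibits these cells, and whether 4-fluorophenyl in place of 3-fluorophenyl changes that inhibition at all.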